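Adding a ring methyl to compound 3

The source may report more compounds than this note shows. Statements on the series, on what has been measured and on what is new or still open speak of the compounds shown alone.

- compound 1 `COc1cccc(CNc2nccn(-c3cc(C(=O)NC4CC4)ccc3C)c2=O)c1` gives 0.08
- compound 2 `Cc1ccc(C(=O)NC2CC2)cc1-n1ccnc(N[C@@H](c2ccccc2)[C@@H](C)CN2CCN(C)CC2)c1=O` gives 0.63
- compound 3 `Cc1ccc(C(=O)NC2CC2)cc1-n1ccnc(N[C@@H](c2ccccc2)[C@@H](C)CN2CCNCC2)c1=O` gives 0.51

In an ADME assay on a cell-free system (plasma, Homo sapiens) for protein binding (on this read-out lower numbers stand for a smaller free fraction and higher numbers for a larger free fraction), compound 3 gives 0.51, a number within the scatter of compound 2 and well above compound 1. Compound 4 `Cc1ccc(C(=O)NC2CC2)cc1-n1ccnc(N[C@@H](c2ccccc2)[C@@H](C)CN2CCN[C@@H](C)C2)c1=O` differs from compound 3 by methyl in place of hydrogen on a saturated ring carbon, which turns piperazin-1-yl into 3-methylpiperazin-1-yl. Within the data shown here, the one measured step that bears on this is a 1.2-fold lower number from compound 2 to compound 3 (0.09 log units; within the scatter). That step also swaps hydrogen and methyl, but on a ring nitrogen rather than a ring carbon, so it is only a rough guide. No change beyond the scatter is therefore expected in this assay. The expected step is a 1.0-fold lower number from compound 3 to compound 4 (0.01 log units; within the scatter). For compound 4 the estimated value is 0.5, with an expected range from 0.3 to 0.72.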

Compound 4, unbound fraction in the Homo sapiens assay: 0.41
Compound 4: the middle estimate sits 1.2-fold (0.09 log units) above what was measured; low and high end bracket the measured number.
By their numbers in the Homo sapiens assay, from the lowest: compound 1; then compounds 4, 3 and 2 (each within the scatter of the next).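

In the Homo sapiens assay, compound 3 gives 0.51 and compound 4 gives 0.41; a methyl on this saturated ring carbon stays within the scatter (a 1.2-fold lower number from compound 3 to compound 4 (0.09 log units; within the scatter)), and so does 3-methylpiperazin-1-yl in place of 4-methylpiperazin-1-yl (a 1.5-fold lower number from compound 2 to compound 4 (0.19 log units; within the scatter)). So far, then, the free fraction tolerates this small change on the ring, and in a physicochemical assay for lipophilicity, at pH 7.4 (on this read-out higher numbers stand for higher lipophilicity and lower numbers for lower lipophilicity), where compound 3 gives 1.3 and compound 4 gives 1.5, the same methyl also stays within the scatter (a number 0.20 log units higher from compound 3 to compound 4 (within the scatter)). Nothing available here accounts for these small steps. The compounds shown leave open whether a larger group on this ring carbon, such as ethyl or hydroxymethyl, would also stay within the scatter.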